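The source may report more compounds than this note shows. Statements on the series, on what has been measured and on what is new or still open speak of the compounds shown alone.

Compound 2 `COc1ccc2[nH]c3c(c2c1)CCNC31CCN(Cc2c(F)ccc(Cl)c2F)CC1` holds the lowest of the two numbers obtained so far in an assay on FRT cells for positive allosteric modulation of Cystic fibrosis transmembrane conductance regulator variant N1303K (Homo sapiens), in the presence of a further agent that is not named here (a higher number here means that more compound is needed for the effect, a lower number that less compound is needed), giving 1500 nM. Within the data shown here, its only neighbour is compound 1 `COc1ccc2[nH]c3c(c2c1)CCNC31CCN(Cc2cc(Cl)ccc2[N+](=O)[O-])CC1`, which in this assay gives 7100 nM; the move between them, a 4.7-fold lower number from compound 1 to compound 2 (0.68 log units; beyond the scatter), was the sole measured step, and it concerned the same aromatic group hanging from the saturated chain carbon bound to an amine nitrogen in a ring. Compound 3 `COc1ccc2[nH]c3c(c2c1)CCNC31CCN(Cc2cc(F)c(F)c(F)c2)CC1` is reached from compound 2 by 3,4,5-trifluorophenyl in place of 3-chloro-2,6-difluorophenyl on a saturated chain carbon bound to an amine nitrogen in a ring. Among the measured compounds shown here, that is again an exchange of one halogenated phenyl for another at the very same place, so the one measured step is the only guide: it was modest, and the present exchange keeps the same count of heavy atoms. Compound 3 is therefore expected to land close to compound 2, with a step of about a 1.7-fold higher number from compound 2 to compound 3 (0.22 log units; within the scatter), which is within the scatter. The estimate for compound 3 in this assay is 2500 nM, ranging from 800 nM to 8000 nM.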

Compound 3, half-maximal effective concentration: 2600 nM
Beside the measured number, compound 3's estimate is 1.0-fold (0.02 log units) below it, within the range that was stated.
By their numbers in this assay, from the lowest: compounds 2 and 3 (each within the scatter of the next); then compound 1.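

In this assay, 3,4,5-trifluorophenyl in place of 3-chloro-2,6-difluorophenyl on a saturated chain carbon bound to an amine nitrogen in a ring gives a 1.7-fold higher number from compound 2 to compound 3 (0.24 log units; within the scatter), so these two halogenated phenyl groups, with the same count of heavy atoms, cannot be told apart here. With a 2.7-fold lower number from compound 1 to compound 3 (0.44 log units; beyond the scatter), a second halogenated phenyl stands clear of the 5-chloro-2-nitrophenyl group, and as the group in compound 3 holds no chlorine, the gain over compound 1 does not require that atom. No evidence bearing on the cause of these differences is at hand. Compound 1 differs from the other two in the whole aromatic group, so the part played by its nitro group alone remains unseparated. As far as these compounds go, whether an unsubstituted phenyl, a methoxyphenyl or a pyridine would fit this place as well also remains open.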